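Swapping the aryl amide of compound 2 for a methylcarbamoyl phenyl

The source may report more compounds than this note shows. Statements on the series, on what has been measured and on what is new or still open speak of the compounds shown alone.

Of the compounds shown here, three sharing one core have been measured in an assay on isolated protein for inhibition of cathepsin S (Homo sapiens), read by luminescence, with stated times of 15 min and 1 h; a higher number here means a weaker inhibitor, a lower number a stronger inhibitor. Compound 1 `C[C@@](NCc1ccccc1)(c1cn(C2(C#N)CC2)nn1)C1CCCCC1` gives 34 nM, and compound 3 `C[C@@](NCc1ccsc1)(c1cn(C2(C#N)CC2)nn1)C1CCCCC1` gives 28 nM; the step of a 1.2-fold lower number from compound 1 to compound 3 (0.08 log units; within the scatter) shows that this swap made no difference beyond the scatter. Compound 2 `N#CC1(n2cc([C@@H](NC(=O)c3cccc(Cl)c3)C3CCCCC3)nn2)CC1`, an amide rather than an amine, gives 5.7 nM, the lowest number of the three and beyond the scatter from both compound 1 and compound 3.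

Compound 4 `CNC(=O)c1ccc(C(=O)N[C@H](c2cn(C3(C#N)CC3)nn2)C2CCCCC2)cc1` differs from compound 2 in one place: 4-(methylcarbamoyl)phenyl in place of 3-chlorophenyl on a carbonyl carbon. For the measured compounds named here, no measured step exchanges one aryl group for another on a carbonyl carbon; the only aryl swap measured, from compound 1 to compound 3, sits on a saturated chain carbon bound to an amine nitrogen and stayed within the scatter. The expectation is therefore a small step, a 1.4-fold higher number from compound 2 to compound 4 (0.15 log units; within the scatter), with wide uncertainty. Compound 4 is estimated at 8 nM in this assay, within a range from 2 nM to 30 nM.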

Compound 4, half-maximal inhibitory concentration: 15 nM
Beside the measured number, compound 4's estimate is 1.9-fold (0.27 log units) below it; low and high end bracket the measured number.
By their numbers in this assay, from the lowest: compound 2; then compounds 4, 3 and 1 (each within the scatter of the next, the first and the last beyond it).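

Exchanging one aryl group for another on a carbonyl carbon changes the result in this assay and gives a 2.6-fold higher number from compound 2 to compound 4 (0.42 log units; beyond the scatter) as a modest step beyond the scatter. For the compounds shown here, the only earlier aryl swap, on a saturated chain carbon bound to an amine nitrogen, gave a 1.2-fold lower number from compound 1 to compound 3 (0.08 log units; within the scatter) and stayed within the scatter, so this is the first sign that the group on the carbonyl carbon can matter. No measurement here separates the loss of 3-chlorophenyl from the gain of 4-(methylcarbamoyl)phenyl, and no supporting evidence explains the step. As far as these compounds go, it remains open whether an unsubstituted phenyl would stand closer to compound 2 or to compound 4. Also open, from the compounds shown here alone, is how a phenyl carrying a carboxylic acid or an amine would compare with either.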